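Cyano in Place of Nitro: Working Notes

This account rests on a few compounds, and the source may have more. Where it says the series, first, only, none or still open, it means among the compounds named here.

Among the compounds with values here, in a functional assay on HL-60 cells (Homo sapiens) for cytotoxicity, read by MTT assay, with a stated time of 46 h (on this read-out higher numbers stand for weaker inhibition and lower numbers for stronger inhibition), compound 3 `O=c1c(Cc2ccc([N+](=O)[O-])cc2)coc2ccccc12` gives 2400 nM, the second highest of the three numbers so far. Compound 2 `O=C1/C(=C/c2ccc(Cl)cc2)C(c2ccccc2)Oc2ccccc21` lies higher at 5800 nM, and compound 1 `O=C1/C(=C/c2ccncc2)C(c2ccccc2)Oc2ccccc21` lies lower at 900 nM. The next change leads to compound 4 `N#Cc1ccc(Cc2coc3ccccc3c2=O)cc1`: cyano in place of nitro on an aromatic carbon. This places cyano in place of nitro on an aromatic carbon, para to a large group.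

Within the data shown here, the only measured step is a 6.4-fold higher number from compound 1 to compound 2 (0.81 log units; beyond the scatter). It exchanges other groups on another core and involves neither nitro nor cyano, so it sets no size for this change. Among the measured compounds shown here, it shows only that a single exchange can move the read-out in this small set. For the measured compounds named here, no measured step supports a direction here, so no shift beyond the scatter is expected. The expected step in this assay is a 1.2-fold higher number from compound 3 to compound 4 (0.07 log units; within the scatter).

For compound 4 the estimated value is 2800 nM, with an expected range of 1100 nM to 7000 nM.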

Compound 4, half-maximal inhibitory concentration: 3800 nM
Compound 4: middle estimate off by 1.4-fold (0.13 log units), on the low side; measured number inside the range.
By their numbers in this assay, from the lowest: compound 1; then compounds 3, 4 and 2 (each within the scatter of the next, the first and the last beyond it).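

In this assay the exchange of nitro for cyano on an aromatic carbon, para to a large group, gives a 1.6-fold higher number from compound 3 to compound 4 (0.20 log units; within the scatter) and so stays inside the usual variation between repeats. Within the data shown here, this is the first reading at this position, and it shows that a group with 3 heavy atoms and 2 hydrogen-bond acceptors can give way to one with 2 heavy atoms and 1 hydrogen-bond acceptor without a read-out change beyond the scatter. No measurement at hand accounts for this outcome.

With only nitro and cyano shown at this place, it remains open whether an amine or a carboxylic acid there would shift the number beyond the scatter. As far as these compounds go, it is equally open whether cyano in place of nitro would behave the same way on the core of compound 1.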